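Replacing the amino chain of compound 3

This account rests on a few compounds, and the source may have more. Where it says the series, first, only, none or still open, it means among the compounds named here.

Measured in a functional assay on HepG2 cells (Homo sapiens), read by MTT assay, with a stated time of 48 h; a higher number here means a weaker inhibitor, a lower number a stronger inhibitor
compound 1 `CCn1c(C(=O)NCCN(C)C)ccc1C(CC)(CC)c1ccc(OCC(=O)C(C)(C)C)c(C)c1` gives 2300 nM
compound 2 `CCN(CC)CCCNC(=O)c1ccc(C(CC)(CC)c2ccc(OCC(=O)C(C)(C)C)c(C)c2)n1CC` gives 180 nM
compound 3 `CCN(CC)CCCNC(=O)c1ccc(C(CC)(CC)c2ccc(OCC(O)C(C)(C)C)c(C)c2)n1CC` gives 1100 nM

On these numbers compound 3 lies between compound 2 and compound 1. Compound 4 `C#CC(C)OC(=O)c1ccc(C(CC)(CC)c2ccc(OCC(O)C(C)(C)C)c(C)c2)n1CC` carries (1-methylprop-2-yn-1-yl)oxy in place of (3-(diethylamino)propyl)amino on a carbonyl carbon. The closest evidence is the large step of a 13-fold lower number from compound 1 to compound 2 (1.11 log units; beyond the scatter), which arose within this same amino chain. The modest step of a 6.1-fold higher number from compound 2 to compound 3 (0.79 log units; beyond the scatter) concerns another group and bears less. Among the measured compounds shown here, no measured compound lacks an amino chain on that carbonyl, so the extrapolation is loose. A clear move to a higher number in this assay is expected, and the expected size is a 4.1-fold higher number from compound 3 to compound 4 (0.61 log units; beyond the scatter). Compound 4 is estimated at 4500 nM, with an expected range of 900 nM to 20000 nM.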

Compound 4, half-maximal inhibitory concentration: > 50000 nM
Compound 4 gave a limit, no number (the forecaster's own chance of this, stated with the estimate: 20%); at least 11-fold (1.04 log units) between middle value and limit.
By their numbers in this assay, from the lowest: compound 2; then compound 3; then compound 1. At a limit, above all of these: compound 4.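

Replacing (3-(diethylamino)propyl)amino on the carbonyl carbon with (1-methylprop-2-yn-1-yl)oxy gives an at least 45-fold higher number from compound 3 to compound 4 (1.65 log units; beyond the scatter) in this assay. Compound 4 is read only as a limit: the limit of > 50000 nM in this assay, at which 1 of the 4 values shown sits. Among the compounds shown here, the earlier compounds all kept an amino chain on this carbonyl, so this is the first sign that activity depends on more than that chain's length or its terminal substituents.

As far as these compounds go, the change removes the amide nitrogen and the diethylamino group together, so their separate contributions remain open. A simple propyl amide or a 3-(diethylamino)propyl ester would separate them.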